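Anilino in Place of Oxopyrrolidinyl on a Fused Core

The source may hold more compounds than are shown below. What is called first, only, known or untested is meant among the compounds shown, and "the series" means these compounds.

Compound 1 `Cn1cc(-c2cnc(NCc3c(F)ccc4c3CCO4)c3cn[nH]c(=O)c23)cn1` gives 2.7 in a physicochemical assay for lipophilicity, using the shake flask method, in phosphate buffer, measured as octanol-water partition, with a stated time of 30 min, at pH 7.4; a lower number here means a more polar compound, a higher number a more lipophilic compound.
Compound 2 `CNC(=O)c1cc(-c2cnc(NCc3c(F)ccc4c3CCO4)c3cn[nH]c(=O)c23)n(C)n1` gives 2.1.
Compound 3 `O=C1CCCN1c1cnc(NCc2c(F)ccc3c2CCO3)n2cnnc12` gives 1.3.

Compound 3 stands lowest of the three in this assay, with compound 2 higher and compound 1 higher still. Among the measured compounds shown here, the single one-place step, a number 0.60 log units lower from compound 1 to compound 2 (beyond the scatter), follows 1-methyl-3-(methylcarbamoyl)-1H-pyrazol-5-yl in place of 1-methyl-1H-pyrazol-4-yl on an aromatic carbon. Compound 4 `Fc1ccc2c(c1CNc1ncc(Nc3ccccc3)c3nncn13)CCO2` differs from compound 3 by anilino in place of 2-oxopyrrolidin-1-yl on an aromatic carbon. For the measured compounds named here, no measured step involves either of these groups, so nothing bears directly on this change; the expectation rests on the exchange itself, a six-membered aromatic ring of carbon only entering for a five-membered non-aromatic ring with one hetero atom. A rise beyond the scatter is expected, about a number 1.20 log units higher from compound 3 to compound 4 (beyond the scatter). Compound 4 is therefore estimated at 2.5, between 1.9 and 3.1.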

Compound 4, distribution coefficient: 3.3
Beside the measured number, compound 4's estimate is 0.80 log units below it; the whole stated range lies below it.
By their numbers in this assay, from the lowest: compound 3; then compound 2; then compound 1; then compound 4.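

Among the compounds shown here, on an aromatic carbon of the six-membered aromatic ring with 2 nitrogen, anilino in place of 2-oxopyrrolidin-1-yl gives a number 2.00 log units higher from compound 3 to compound 4 (beyond the scatter) in this assay, the only measured change at this place and a large one. The two groups differ at once in ring type and in hydrogen-bond donors, so the step cannot be assigned to either difference alone. Nothing at hand accounts for its size. Going by these compounds, whether cyclohexylamino, with a non-aromatic ring, or a plain amine would stand nearer compound 3 or compound 4 remains open.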